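The source may report more compounds than this note shows. Statements on the series, on what has been measured and on what is new or still open speak of the compounds shown alone.

Compound 1 `COc1cc(/C=C/C(=O)C2=C(/C=C/c3ccc(O)c(OC)c3)NC(=O)NC2c2ccccc2)ccc1O`: 15.2%
Compound 2 `COc1cc(/C=C/C(=O)C2=C(/C=C/c3ccc(O)c(OC)c3)NC(=O)NC2c2c(Cl)cccc2Cl)ccc1O`: 11.2%

In a functional assay, with a stated time of 20 min, tested at 2 uM (on this read-out higher numbers stand for a stronger effect at the one concentration tested and lower numbers for a weaker effect), compound 2 gives 11.2% and compound 1 gives 15.2%, so the two stand within the scatter of each other. Compound 3 `COc1cc(/C=C/C(=O)C2=C(/C=C/c3ccc(O)c(OC)c3)NC(=O)NC2c2ccccc2Cl)ccc1O` differs from compound 2 by hydrogen in place of chloro on an aromatic carbon. Among the compounds with values here, the one measured step that bears on this, a number 4 percentage points lower from compound 1 to compound 2 (within the scatter), was within the scatter, and compound 3 lies between those two structures. No step beyond the scatter is therefore expected in this assay, in either direction. The expected step is a number 1.8 percentage points higher from compound 2 to compound 3 (within the scatter). Compound 3 is estimated to give 13%, between 3% and 23%.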

Compound 3, a percentage reported as activity, at one concentration (the size of the read-out at that concentration, not a potency): 20.2%
The estimate for compound 3 lay 7.2 percentage points below the measured number; the measured number falls inside the stated range.
By their numbers in this assay, from the lowest: compounds 2, 1 and 3 (each within the scatter of the next).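

The step from 2,6-dichlorophenyl to 2-chlorophenyl is a number 9 percentage points higher from compound 2 to compound 3 (within the scatter) in this assay, and the step from phenyl to 2-chlorophenyl is a number 5 percentage points higher from compound 1 to compound 3 (within the scatter). The phenyl, 2-chlorophenyl and 2,6-dichlorophenyl compounds therefore all stand within the scatter of one another, so neither change to chloro on this aromatic ring gives a step that can be told from the scatter. Nothing available explains these numbers. Going by these compounds, it remains open whether a different group on this ring, such as an amine, a nitrile or a carboxylic acid, would give a step beyond the scatter.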